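Ring substitution on the shared core of compound 1

The source may hold more compounds than are shown below. What is called first, only, known or untested is meant among the compounds shown, and "the series" means these compounds.

Measured compounds:
compound 1, `O=C(Nc1cccc(Cl)c1)Nc1ccc(-c2cc(=O)c3ccccc3o2)c(Cl)c1`, 48.9%
compound 2, `O=C(Nc1cccc(Cl)c1)Nc1ccc(-c2cc(=O)c3cc(F)ccc3o2)c(Cl)c1`, 26.8%

In an ADME assay on QSG7701 cells (Homo sapiens) for inhibition, read by MTT assay, with a stated time of 48 h, tested at 50 uM (a lower number here means a weaker effect, a higher number a stronger effect of the compound at the concentration tested), compound 1 gives 48.9%, the higher of the two numbers, while compound 2 gives 26.8%. Among the compounds with values here, the single measured step, a number 22.1 percentage points lower from compound 1 to compound 2 (beyond the scatter), is the only guide available. Compound 3, `O=C(Nc1cccc(Cl)c1)Nc1ccc(-c2cc(=O)c3ccc(O)cc3o2)c(Cl)c1`, differs from compound 1 by hydroxy in place of hydrogen on an aromatic carbon. That change is of another kind and at another place than the measured step, so it bears on the question only loosely; since one substitution on the core lowered the number, a modest decrease is expected here as well, a number 8.9 percentage points lower from compound 1 to compound 3 (within the scatter). Compound 3 is therefore expected to give 40%, in the range 20% to 60%.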

Compound 3, a percentage reported as inhibition, at one concentration (the size of the read-out at that concentration, not a potency): 34.6%
The estimate for compound 3 lay 5.4 percentage points above the measured number; the range from low to high includes it.
By their numbers in this assay, from the lowest: compounds 2 and 3 (each within the scatter of the next); then compound 1.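

Hydroxy on an aromatic carbon, meta to a fused ring and para to a fused ring, goes with a number 14.3 percentage points lower from compound 1 to compound 3 (beyond the scatter) in this assay and so also lowers the number. With a number 22.1 percentage points lower from compound 1 to compound 2 (beyond the scatter) for fluoro, both substitutions on the shared core of compound 1 point the same way, though they differ in both group and place. Nothing available explains either drop.

Open, on these data alone, is whether an amine or a methoxy group at the hydroxy place would lower the number too, and whether hydroxy and fluoro would give similar steps at one common place.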